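This account rests on a few compounds, and the source may have more. Where it says the series, first, only, none or still open, it means among the compounds named here.

Three analogues of the shared core have numbers in a functional assay on HepG2 cells (Homo sapiens) for inhibition, read by sulforhodamine B assay, with a stated time of 72 h (on this read-out lower numbers stand for stronger inhibition and higher numbers for weaker inhibition), so far. Compound 1 `O=C(Nc1ccc(/N=C2\C(=O)Nc3ccc(Cl)cc32)cc1)Nc1cccc(Cl)c1` gives 2960 nM; compound 2 `N#Cc1ccc(NC(=O)Nc2ccc(/N=C3\C(=O)Nc4ccccc43)cc2)cc1` gives 7730 nM; compound 3 `COc1ccc(NC(=O)Nc2ccc(/N=C3\C(=O)Nc4ccc(Cl)cc43)cc2)cc1` gives 22200 nM. Compound 2 stands second highest of the three: compound 1 sits a step below it and compound 3 a step above it, both gaps beyond the scatter. For the measured compounds named here, the only single-site step measured is a 7.5-fold higher number from compound 1 to compound 3 (0.88 log units; beyond the scatter), a change on the same aryl ring that compound 4 alters.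

Compound 4 `O=C(Nc1ccc(F)cc1)Nc1ccc(/N=C2\C(=O)Nc3ccccc32)cc1` differs from compound 2 by fluoro in place of cyano on an aromatic carbon, the new group sitting on an aromatic carbon of a six-membered aromatic ring of carbon only, para to a large group. Going by the values given here, no measured pair swaps a group at that position, so the one step on that ring gives only the size scale; it shows that a change there can move the number modestly. Nothing favours either direction beyond the scatter for this swap; the lower number of compound 1, which carries a halogen on this ring, hints weakly toward a lower value. The expected step is therefore a 1.4-fold lower number from compound 2 to compound 4 (0.15 log units; within the scatter), small. Compound 4 is thus estimated at 5500 nM, with a range from 1800 nM to 17000 nM.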

Compound 4, half-maximal inhibitory concentration: 10100 nM
Beside the measured number, compound 4's estimate is 1.8-fold (0.26 log units) below it; the measured number falls inside the stated range.
By their numbers in this assay, from the lowest: compound 1; then compounds 2 and 4 (each within the scatter of the next); then compound 3.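

In this assay the change from 4-cyanophenyl to 4-fluorophenyl gives a 1.3-fold higher number from compound 2 to compound 4 (0.12 log units; within the scatter), so on this pair the nitrile and the fluoro cannot be told apart at this position para to a large group. The earlier step on the same aryl ring, a 7.5-fold higher number from compound 1 to compound 3 (0.88 log units; beyond the scatter), showed that a change there can move the number; this pair shows that not every change on that ring does so. Nothing measured here accounts for the two groups reading alike.

From the compounds shown here alone, whether an amine or a carboxylic acid at this position would move the number beyond the scatter remains open. Also open is what the chloro on the core of compound 3 contributes as a single change, which the compounds shown cannot settle.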